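This account rests on a few compounds, and the source may have more. Where it says the series, first, only, none or still open, it means among the compounds named here.

Compound 1 `COc1ccc(-c2nc(C)c(C(=O)CSc3nc(-c4ccc(OC)cc4)c(C#N)c(=O)[nH]3)s2)cc1` sits second highest of the three numbers in a functional assay on U-87MG ATCC cells for antiproliferative activity against U-87 MG (Homo sapiens), read by MTT assay, with a stated time of 48 h (on this read-out lower numbers stand for stronger inhibition and higher numbers for weaker inhibition), where compound 1 gives 25300 nM. The nearest value belongs to compound 3 `COc1ccc(-c2nc(C)c(C(=O)CSc3nc(-c4ccc(Cl)c(Cl)c4)c(C#N)c(=O)[nH]3)s2)cc1`, which gives 68500 nM; the furthest belongs to compound 2 `COc1ccc(-c2nc(C)c(C(=O)CSc3nc(N)c(C#N)c(-c4ccc(OC)cc4)n3)s2)cc1`, built on a different core, which gives 1560 nM.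

Compound 4 `COc1ccc(-c2nc(SCC(=O)c3sc(-c4ccc(Cl)cc4)nc3C)[nH]c(=O)c2C#N)cc1` is the unmeasured member. Against compound 1 the difference reads (chloro in place of methoxy on an aromatic carbon), a chloro in place of methoxy on an aromatic carbon, para to a large group; cut one bond further out it reads 4-methoxyphenyl to 4-chlorophenyl.

Among the compounds with values here, only one measured step bears on this: a 2.7-fold higher number from compound 1 to compound 3 (0.43 log units; beyond the scatter), where 3,4-dichlorophenyl replaced 4-methoxyphenyl and a modest rise in number followed. Compound 4 carries a single chloro rather than two, and the exchange is not on the same aromatic carbon as in compound 3, so the guidance is indirect. Within the data shown here, no measured pair shows a methoxy to chloro swap alone.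

On that basis a small rise in number, at the edge of the scatter, is expected in this assay, amounting to a 1.6-fold higher number from compound 1 to compound 4 (0.20 log units; within the scatter). Compound 4 is estimated at 40000 nM, with a range from 15000 nM to 110000 nM in this assay.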

Compound 4, half-maximal inhibitory concentration: 35500 nM
Beside the measured number, compound 4's estimate is 1.1-fold (0.05 log units) above it; low and high end bracket the measured number.
By their numbers in this assay, from the lowest: compound 2; then compounds 1, 4 and 3 (each within the scatter of the next, the first and the last beyond it).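

In this assay the exchange of 4-methoxyphenyl for 4-chlorophenyl gives a 1.4-fold higher number from compound 1 to compound 4 (0.15 log units; within the scatter) and so leaves the read-out unresolved from that of compound 1: at this aromatic carbon, a chloro can stand in place of methoxy with no change beyond the scatter. This position is a different one from the aromatic carbon changed in compound 3, and the 3,4-dichlorophenyl exchange there gives a 2.7-fold higher number from compound 1 to compound 3 (0.43 log units; beyond the scatter), so the two steps from compound 1 describe separate sites and differ in the substituents entering, which means they cannot be read as a single trend. No measurement of any property of these compounds is available to explain the result.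

The compounds shown leave open whether this tolerance extends to other groups at the same carbon, such as an amine, a carboxylic acid or an unsubstituted phenyl, since a single exchange marks out only one point. Also open, on these data alone, is whether a single chloro on the other 4-methoxyphenyl would behave in the same way, and whether the exchange would hold on the different core of compound 2.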